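The source may report more compounds than this note shows. Statements on the series, on what has been measured and on what is new or still open speak of the compounds shown alone.

Of the compounds shown here, two of a shared core have been tested for agonist activity in a functional assay on HEK293 cells for agonist activity at G-protein coupled receptor 39 (Homo sapiens), read by scintillation proximity assay and inositol phosphate accumulation, with a stated time of 75 min, in the presence of a further agent that is not named here; on this read-out lower numbers stand for an effect already at smaller amounts and higher numbers for an effect only at larger amounts of compound. Compound 1 `Cc1nn(-c2ncnc3nc[nH]c23)c2c1C(OCC(=O)c1ccc(F)cc1)CC(=O)N2` gives 3 nM in this assay. Compound 2 `Cc1noc(C)c1COC1CC(=O)Nc2c1c(C)nn2-c1ncnc2nc[nH]c12` gives 5 nM in this assay, the highest of the two numbers, though its difference from compound 1 is within the scatter. Within the data shown here, the one measured step, a 1.7-fold higher number from compound 1 to compound 2 (0.22 log units; within the scatter), replaced a (4-fluorophenyl)carbonyl group with a 3,5-dimethyl-1,2-oxazol-4-yl group on a saturated chain carbon bound to an oxygen on a saturated carbon, and left the read-out essentially unchanged.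

Compound 3 `Cc1nn(-c2ncnc3nc[nH]c23)c2c1C(OCc1ccc(C#N)cc1)CC(=O)N2` has not yet been measured in this assay. It differs from compound 2 in one place: 4-cyanophenyl in place of 3,5-dimethyl-1,2-oxazol-4-yl on a saturated chain carbon bound to an oxygen on a saturated carbon. The same site has thus already carried two quite different groups without a step beyond the scatter. Among the measured compounds shown here, that single step is the only one bearing on this change, and on its basis no step beyond the scatter is expected for compound 3 in this assay. The expected step for compound 3 is no change at the digits printed from compound 2 to compound 3 (within the scatter). Compound 3 is therefore estimated at 5 nM in this assay, with a range from 1.5 nM to 16 nM.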

Compound 3, half-maximal effective concentration: 4 nM
Estimate against measurement, compound 3: 1.3-fold (0.10 log units) above; low and high end bracket the measured number.
By their numbers in this assay, from the lowest: compounds 1, 3 and 2 (each within the scatter of the next).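

With compound 3, the site on a saturated chain carbon bound to an oxygen on a saturated carbon has now carried a third group in this assay, and this group is a six-membered aromatic ring of carbon only, bearing a nitrile. Among these compounds, the read-out stays within the scatter on both comparisons, with a 1.3-fold lower number from compound 2 to compound 3 (0.10 log units; within the scatter) and a 1.3-fold higher number from compound 1 to compound 3 (0.12 log units; within the scatter), so the tolerance seen in the single earlier step now holds across three groups: 4-cyanophenyl, 3,5-dimethyl-1,2-oxazol-4-yl and (4-fluorophenyl)carbonyl. Nothing shown here explains why such different groups give numbers this close, and the flat result alone cannot supply a reason.

All three groups contain an aromatic ring and carry no net charge, so these compounds cannot tell whether an aromatic ring is needed at this site or whether a plain methyl group would serve as well. From the compounds shown here alone, it also remains open whether the number would stay within the scatter with an amine, a carboxylic acid or a longer chain at this place.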